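This account rests on a few compounds, and the source may have more. Where it says the series, first, only, none or still open, it means among the compounds named here.

Compound 1: `CNC(=O)c1cc(Oc2ccc(NC(=O)c3cc(-c4ccc(F)cc4)ncn3)cc2)ccn1`
Compound 2: `CNC(=O)c1cc(Oc2ccc(NC(=O)c3cc(-c4ccccc4)ncn3)cc2)ccn1`

In a functional assay on A549 cells (Homo sapiens) for cytotoxicity, read by MTT assay, with a stated time of 72 h (on this read-out lower numbers stand for stronger inhibition and higher numbers for weaker inhibition), compound 1 is reported only as a limit, > 100000 nM. In this assay, among the measured compounds shown here, compound 2 gives 27100 nM, the only number among the two values shown. The other value, that of compound 1, is a limit rather than a number: the limit of > 100000 nM in this assay, at which 1 of the 2 values shown sits. For the measured compounds named here, the one measured step runs an at least 3.6-fold lower number from compound 1 to compound 2 (0.56 log units; beyond the scatter), so taking the fluoro off that aromatic carbon lowered the number in this assay by a modest amount.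

Compound 3 is `CNC(=O)c1cc(Oc2ccc(NC(=O)c3cc(-c4ccc(Br)cc4)ncn3)cc2)ccn1`. Its difference from compound 2 is bromo in place of hydrogen on an aromatic carbon. This is the same position where compound 1 carries its fluoro, and compound 1 sits at the limit of this assay. Going by the values given here, the only step that bears on the change, an at least 3.6-fold lower number from compound 1 to compound 2 (0.56 log units; beyond the scatter), shows that a halogen at this place raises the number, so a rise is expected when bromo enters. Compound 3 is therefore expected to give a weaker result in this assay, with a step of a 3.0-fold higher number from compound 2 to compound 3 (0.47 log units; beyond the scatter), and may well reach the limit again. The estimate for compound 3 in this assay is 80000 nM, within 30000 nM to 200000 nM.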

Compound 3, half-maximal inhibitory concentration: > 100000 nM
Compound 3: no number, only a limit (the forecaster's own chance of this, stated with the estimate: 45%); at least 1.2-fold (0.09 log units) between middle value and limit.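

In this assay, the change from phenyl to 4-bromophenyl gives an at least 3.6-fold higher number from compound 2 to compound 3 (0.56 log units; beyond the scatter), so a second halogen on this aromatic carbon moves the number the same way that fluoro did, and the hydrogen of compound 2 remains the only substituent here with a measured number. The result for compound 3 is a limit and not a number, and compound 1 stands at the same limit: the limit of > 100000 nM in this assay, at which 2 of the 3 values shown sit. The steps between compound 1 and compound 3 cannot be read, so the compounds shown do not place fluoro and bromo in any order.

Going by these compounds, it remains open whether the rise belongs to halogens alone or to any group that replaces hydrogen at this place, a question that a methyl, a methoxy or an amine could begin to answer. On these data alone, it is also open whether any group here could give a lower number than the hydrogen of compound 2, and how far compound 1 and compound 3 lie beyond their limit.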